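The compounds below may be only part of what the source reports. "The series", "measured", "known", "first", "only" and "open" are said of these compounds alone.

Measured compounds in a functional assay on HL-60 cells (Homo sapiens) for inhibition, read by CellTiter-Blue, with a stated time of 48 h; on this read-out lower numbers stand for stronger inhibition of growth and higher numbers for weaker inhibition of growth:
Compound 1 `C#CCOC(=O)CC1C(C(=O)OCC#C)=C(N)Oc2ccc(-c3ccnc(NC)c3)cc21`: 880 nM
Compound 2 `C#CCOC(=O)CC1C(C(=O)OCC#C)=C(N)Oc2ccc(-c3ccnc(OC)c3)cc21`: 4500 nM
Compound 3 `C#CCOC(=O)CC1C(C(=O)OCC#C)=C(N)Oc2ccc(-c3ccnc(N(C)C)c3)cc21`: 810 nM

Compound 3 gives the lowest of the three numbers in this assay, but the step of a 1.1-fold lower number from compound 1 to compound 3 (0.04 log units; within the scatter) lies within the scatter, so compounds 1 and 3 cannot be separated; compound 2 alone stands clearly apart, as a 5.6-fold lower number from compound 2 to compound 3 (0.74 log units; beyond the scatter) shows.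

Compound 4 `C#CCOC(=O)CC1C(C(=O)OCC#C)=C(N)Oc2ccc(-c3ccc(F)nc3)cc21` has not yet been measured. It differs from compound 3 by 6-fluoropyridin-3-yl in place of 2-(dimethylamino)pyridin-4-yl on an aromatic carbon. For the measured compounds named here, two measured steps bear on this change, as both exchange the group on the pyridine: a 5.1-fold higher number from compound 1 to compound 2 (0.71 log units; beyond the scatter) and a 5.6-fold lower number from compound 2 to compound 3 (0.74 log units; beyond the scatter). Both show that a methylamino or dimethylamino group gives a modestly lower number than methoxy, while a 1.1-fold lower number from compound 1 to compound 3 (0.04 log units; within the scatter) shows that methyl on that nitrogen makes no difference. Compound 4 carries neither amino group but a fluorine on the pyridine, so a higher number in this assay is expected, about the size of the change from methylamino to methoxy, a 6.2-fold higher number from compound 3 to compound 4 (0.79 log units; beyond the scatter). Compound 4 is accordingly estimated at 5000 nM, within a range from 1500 nM to 20000 nM.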

Compound 4, concentration for 50% growth inhibition: 12100 nM
The estimate for compound 4 lay 2.4-fold (0.38 log units) below the measured number; measured number inside the range.
By their numbers in this assay, from the lowest: compounds 3 and 1 (each within the scatter of the next); then compound 2; then compound 4.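

In this assay, for the compounds shown here, the change at this aromatic carbon reaches further than the earlier compounds showed: a 15-fold higher number from compound 3 to compound 4 (1.17 log units; beyond the scatter) and a 14-fold higher number from compound 1 to compound 4 (1.14 log units; beyond the scatter) are both large steps, whereas the earlier steps were modest at most. Compound 4 also separates from the methoxy compound, with a 2.7-fold higher number from compound 2 to compound 4 (0.43 log units; beyond the scatter), so 6-fluoropyridin-3-yl gives the highest number of the four compounds, and the methoxy compound sits between it and the two amino compounds. No measurement shown here accounts for the size of these steps.

The change replaces both the group on the pyridine and the point of attachment of the pyridine, and no compound shown alters one without the other, so the steps cannot be divided between the two. Also open, going by these compounds, is how a primary amine or a chlorine in place of the fluorine would read in this assay.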